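Aryl amine variation on a shared core

The source may hold more compounds than are shown below. What is called first, only, known or untested is meant among the compounds shown, and "the series" means these compounds.

Compound 1 `O=C1C=C(Nc2ccccc2F)C(=O)c2c1nc1n2[C@H]2OC[C@@H](O)[C@H]2OC1` carries a 2-fluorophenyl group on the amine nitrogen whose other neighbour is a double-bonded ring carbon. In a functional assay on MCF7 cells (Homo sapiens) for inhibition, read by sulforhodamine B assay (a higher number here means a weaker inhibitor, a lower number a stronger inhibitor), compound 1 gives 3640 nM. Compound 2 `O=C1C(N2CCC2)=CC(=O)c2c1nc1n2[C@H]2OC[C@@H](O)[C@H]2OC1` carries an azetidine on the corresponding position and in this assay is reported only as a limit, > 16000 nM, not as a number. Going by the values given here, compound 1 therefore stands as the only numerical value in the set; the other entry is the limit of > 16000 nM in this assay, at which 1 of the 2 values shown sits. Among the compounds with values here, no pair of measured compounds differs in a single place, so no measured step is available.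

Compound 3 `COc1cccc(NC2=CC(=O)c3nc4n(c3C2=O)[C@H]2OC[C@@H](O)[C@H]2OC4)c1` differs from compound 1 by 3-methoxyphenyl in place of 2-fluorophenyl on an amine nitrogen. Within the data shown here, with no measured step to lean on, the change from compound 1 to compound 3 is expected to lie within the usual scatter, a 1.1-fold higher number from compound 1 to compound 3 (0.04 log units; within the scatter), in either direction. Compound 3 is accordingly expected to give about 4000 nM, somewhere between 1500 nM and 12000 nM.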

Compound 3, half-maximal inhibitory concentration: > 4000 nM
Compound 3 ended at the assay's limit (the forecaster's own chance of this, stated with the estimate: 15%); the middle value lies on the limit itself.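

Across the aryl amines, an at least 1.0-fold higher number from compound 1 to compound 3 (0.04 log units; that floor lies within the scatter), the first step readable at this amine nitrogen. Compound 3 is reported in this assay only as a limit, > 4000 nM, not as a number. With that floor inside the scatter, 3-methoxyphenyl in place of 2-fluorophenyl shows no separation between the two compounds, and the true size of the step could still be small or large.

Open, going by these compounds, is whether the fluorine or the methoxy group carries any weight here, since the swap changes both the substituent and its place on the ring. An unsubstituted phenyl or a 3-fluorophenyl on the same amine nitrogen would bear on that, provided it returned a number rather than a limit.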